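Cyclopentyl to 4-chlorophenyl on the shared core

A few compounds are considered here, and "the series" means these few. Any claim that something is new, unique, unknown or untested is made for them only; others in the source may bear on it.

These notes cover a small series built on the shared core of compound 1 (`COc1cc(NC(C)CCCNC(=O)NNC(=O)/C(C)=C/c2ccccc2)c2ncccc2c1`). Going by the values given here, in an ADME assay on L6 cells (Rattus norvegicus) for cytotoxicity, read by resazurin assay, with a stated time of 70 h (a lower number here means a stronger inhibitor, a higher number a weaker inhibitor), compound 1 gives 36500 nM, which is the only number available so far. In this assay compound 2 (`COc1cc(NC(C)CCCNC(=O)NNC(=O)NC(CO)(CO)CO)c2ncccc2c1`) stands as "not determined" (no result reported). In this assay compound 3 (`COc1cc(NC(C)CCCNC(=O)NNC(=O)NC2CCCC2)c2ncccc2c1`) stands as "not determined" (no result reported), so it holds no place on the scale and cannot serve as a baseline for the next compound.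

That next compound is compound 4 (`COc1cc(NC(C)CCCNC(=O)NNC(=O)Nc2ccc(Cl)cc2)c2ncccc2c1`), still to be measured in this assay. The structural change is 4-chlorophenyl in place of cyclopentyl on an amide-type nitrogen. In words, 4-chlorophenyl stands in place of cyclopentyl on an amide-type nitrogen.

Among the compounds with values here, no measured pair isolates this change, so the size of the step cannot be read from the data and any expectation rests on a single anchor. Compound 4 is expected to land in the same general region as compound 1 at 36500 nM, with a modest move toward the lower, more inhibitory side that may not clear the usual scatter. The range is kept wide for that reason.

For compound 4 the estimated value is 22000 nM, with an expected range of 6000 nM to 80000 nM.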

Compound 4, half-maximal inhibitory concentration: 91900 nM
Compound 4: the middle estimate sits 4.2-fold (0.62 log units) below what was measured; the measured number lies above the stated range.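

In this assay the series now has its first readable step, a 2.5-fold higher number from compound 1 to compound 4 (0.40 log units; beyond the scatter), with (4-chlorophenyl)amino in place of 1-methyl-2-phenylethenyl on a carbonyl carbon. This shows that the group at this position can shift the read-out, here toward the weaker side, although the step is modest. The change from cyclopentyl to 4-chlorophenyl cannot itself be read, as compound 3 has no number, and the steps to compound 2 cannot be read either; nothing at hand accounts for the direction or size of the step from compound 1 to compound 4.

With only compound 1 and compound 4 on the scale, the compounds shown leave open how much of the step belongs to the aromatic ring, how much to its chlorine and how much to the amino link on the carbonyl carbon. An unsubstituted phenyl or a 4-methoxyphenyl on the amide-type nitrogen would help separate these contributions, and a carboxylic acid on the same ring would test whether the read-out moves further at this position.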